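The compounds below may be only part of what the source reports. "The series", "measured", "known", "first", "only" and "open" are said of these compounds alone.

Working notes on the series:

- Compound 1 `CSC1=N/C(=C\c2cn(CCCCCOc3ccc(C#N)cc3)c3ccccc23)C(=O)N1`: > 100 ug/mL
- Compound 2 `CSC1=N/C(=C\c2cn(CCCCCOc3ccc(C#N)cc3)c3ccccc23)C(=O)N1C`: > 100 ug/mL

Both entries are limits of an ADME assay on J774.A1 cells (Mus musculus) for cytotoxicity, read by MTT assay (a lower number here means a stronger inhibitor, a higher number a weaker inhibitor), not numbers. The position of compound 2 is therefore known only as > 100 ug/mL. For the measured compounds named here, the series so far offers only (the limit of > 100 ug/mL in this assay, at which 2 of the 2 values shown sit).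

Compound 3 `CN1C(=S)NC(=O)/C1=C\c1cn(CCCCCOc2ccc(C#N)cc2)c2ccccc12` is the next to be read. Its difference from compound 2 is as follows: a group of 9 heavy atoms (5 carbon, 2 nitrogen, 1 oxygen, 1 sulfur; one five-membered non-aromatic ring with 2 hetero atoms) in place of a group of 10 heavy atoms (6 carbon, 2 nitrogen, 1 oxygen, 1 sulfur; one five-membered non-aromatic ring with 2 hetero atoms), on an aromatic carbon.

Going by the values given here, the one measured step is a step that the two limits leave unreadable from compound 1 to compound 2, a methyl in place of hydrogen on an amide-type nitrogen in a ring. It gives no size to carry over. No step beyond the scatter is expected in this assay, and no direction can be assigned. The expected step is a number no higher from compound 2 to compound 3 (the limit leaves the size open). Compound 3 is estimated at 100 ug/mL, with an expected range of 50 ug/mL to 200 ug/mL.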

Compound 3, half-maximal inhibitory concentration: 14.8 ug/mL
For compound 3 the middle estimate is 6.8-fold (0.83 log units) above the measured one; the whole stated range lies above it.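

In this assay compound 3 is the first compound shown to give a number and not a limit, so the group on this aromatic carbon of the five-membered aromatic ring can move the read-out. The change gives an at least 6.7-fold lower number from compound 2 to compound 3 (0.82 log units; beyond the scatter) and a second comparison gives an at least 6.7-fold lower number from compound 1 to compound 3 (0.82 log units; beyond the scatter) with leaving and entering groups of equal heavy-atom count, so heavy-atom count alone does not account for the shift. Compound 1 and compound 2 remain at a limit, which leaves the step between them unreadable: the limit of > 100 ug/mL in this assay, at which 2 of the 3 values shown sit.

From the compounds shown here alone, whether the number would shift again with an amine or a carboxylic acid on the group of 9 heavy atoms stays open. So does the effect of a longer chain or of a carboxylic acid in place of the nitrile.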